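Heptyl Chain to Cyclohexyl Ring on an Ester

The compounds below may be only part of what the source reports. "The series", "measured", "known", "first", "only" and "open" are said of these compounds alone.

Three compounds have been measured in an ADME assay on a cell-free system (plasma, Homo sapiens) for metabolic stability; a higher number here means that the compound lasts longer, a lower number that the compound disappears faster:

Compound 1, `CCOC(=O)CN(C)C(=O)OCN(c1ccc([N+](=O)[O-])cc1Oc1ccccc1)S(C)(=O)=O`: 49.2 h
Compound 2, `CCCCCCCC(=O)OC[C@H]1O[C@@H](n2cnc3c(NC4CCCC4)ncnc32)[C@H](O)[C@@H]1O`: 0.467 h
Compound 3, `CCCCC(=O)OCn1cnc2c1c(=O)n(C)c(=O)n2C`: 0.00317 h

Compound 2 stands second highest of these three. Compound 1 lasts far longer than compound 2, and compound 3 disappears far faster; both gaps lie well beyond the usual scatter of this assay. Compound 2 is therefore the middle point of a wide spread.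

Compound 4, `O=C(OC[C@H]1O[C@@H](n2cnc3c(NC4CCCC4)ncnc32)[C@H](O)[C@@H]1O)C1CCCCC1`, has not yet been measured. It keeps the whole of compound 2 except for one group on the ester: cyclohexyl in place of heptyl on a carbonyl carbon. Among the measured compounds shown here, no pair of measured compounds shows this particular change, so nothing in the data states its size directly. Keeping the same core and the same ester link, a change of this kind is expected to move the half-life only modestly, most likely upward, with a fair chance that the step of a 2.6-fold higher number from compound 2 to compound 4 (0.41 log units; beyond the scatter) stays within the scatter. Compound 4 is estimated to reach 1.2 h, with a plausible range from 0.4 h to 4 h.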

Compound 4, half-life: 0.75 h
Estimate against measurement, compound 4: 1.6-fold (0.20 log units) above; measured number inside the range.
By their numbers in this assay, from the lowest: compound 3; then compounds 2 and 4 (each within the scatter of the next); then compound 1.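

In this assay, among the compounds shown here, the move from heptyl to cyclohexyl on a carbonyl carbon gives a 1.6-fold higher number from compound 2 to compound 4 (0.21 log units; within the scatter), the first direct reading of a change at this place on the ester. An open chain and a six-membered ring of carbon only therefore cannot be told apart on this read-out, at least on the shared core of these two compounds. Nothing measured here offers an explanation for this result.

Still open, as far as these compounds go, is whether a group with atoms other than carbon at this place, such as an amine or a carboxylic acid on the acyl group, would leave the half-life just as unmoved. Also open, from the compounds shown here alone, is whether a much shorter chain, such as methyl, or an aromatic phenyl ring would do the same.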